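Ethyl for Cyclopropyl at One Nitrogen

A few compounds are considered here, and "the series" means these few. Any claim that something is new, unique, unknown or untested is made for them only; others in the source may bear on it.

compound 1 `CCn1cc(C(=O)O)c(=O)c2cc(F)c(N3CCN(C(=N)NS(=O)(=O)c4ccccc4)CC3)cc21`: 71 nM
compound 2 `N=C(NS(=O)(=O)c1ccccc1C(F)(F)F)N1CCN(c2cc3c(cc2F)c(=O)c(C(=O)O)cn3C2CC2)CC1`: 71 nM

In a functional assay on A549 cells (Homo sapiens) for antiproliferative activity, read by MTT assay, with a stated time of 72 h (on this read-out lower numbers stand for stronger inhibition and higher numbers for weaker inhibition), compound 1 stands level with compound 2 at 71 nM, so the two cannot be told apart. Compound 3 `CCn1cc(C(=O)O)c(=O)c2cc(F)c(N3CCN(C(=N)NS(=O)(=O)c4ccccc4C(F)(F)F)CC3)cc21` has one change from compound 2: ethyl in place of cyclopropyl on an aromatic nitrogen. For the measured compounds named here, no single-change step has been measured yet. Compound 1 also carries ethyl on this nitrogen and gives 71 nM, so no large shift seems likely. In this assay, the expected no change at the digits printed from compound 2 to compound 3 (within the scatter) lies within the scatter. Compound 3 is expected at 71 nM, with an estimated range of 30 nM to 170 nM.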

Compound 3, half-maximal inhibitory concentration: 71 nM
Beside the measured number, compound 3's estimate shows no gap at the digits printed; measured number inside the range.
By their numbers in this assay, from the lowest: compounds 1, 2 and 3 (each within the scatter of the next).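

In this assay, ethyl in place of cyclopropyl on the aromatic nitrogen gives no change at the digits printed from compound 2 to compound 3 (within the scatter), and trifluoromethyl in place of hydrogen on an aromatic carbon gives no change at the digits printed from compound 1 to compound 3 (within the scatter). These single-change steps show that neither swap separates the compounds on this read-out, with each change now read on its own. No supporting data explain this flat result.

Still open, as far as these compounds go, is whether a longer chain, such as butyl, or a phenyl group on that nitrogen would shift the value. An amine or a carboxylic acid in place of trifluoromethyl on the aromatic carbon is equally untested here.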